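From 4-methoxyphenyl to 2-methoxyphenyl on the amide nitrogen

A few compounds are considered here, and "the series" means these few. Any claim that something is new, unique, unknown or untested is made for them only; others in the source may bear on it.

In a functional assay on the whole organism for inhibition, with Rattus norvegicus as the target, read by paw edema, with stated times of 30 min and 3 h, at a dose of 0.28 mmol/kg by the oral route (on this read-out lower numbers stand for less inhibition and higher numbers for more inhibition at the one dose given (going by the name of the read-out)), three compounds have been measured:
compound 1, `CNC(=O)c1nc(-c2cc(OC)c(OC)c(OC)c2)n(-c2ccc(OC)cc2)n1`, gives 74%;
compound 2, `CCNC(=O)c1nc(-c2cc(OC)c(OC)c(OC)c2)n(-c2ccc(OC)cc2)n1`, gives 69%;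
compound 3, `COc1ccc(NC(=O)c2nc(-c3cc(OC)c(OC)c(OC)c3)n(-c3ccc(OC)cc3)n2)cc1`, gives 67%.

Compound 3 sits together with the other two: a number 2 percentage points lower from compound 2 to compound 3 (within the scatter) and a number 7 percentage points lower from compound 1 to compound 3 (within the scatter), so the three numbers cannot be told apart. Compound 4, `COc1ccc(-n2nc(C(=O)Nc3ccccc3OC)nc2-c2cc(OC)c(OC)c(OC)c2)cc1`, differs from compound 3 only in the group on the amide nitrogen: 2-methoxyphenyl in place of 4-methoxyphenyl on an amide-type nitrogen. The measured steps all swap that same group, from methyl to ethyl a number 5 percentage points lower from compound 1 to compound 2 (within the scatter) and from the small chains to 4-methoxyphenyl a number 7 percentage points lower from compound 1 to compound 3 (within the scatter), and none moved the read-out beyond the scatter in this assay. Within the data shown here, no measured pair tells where the methoxy sits on that phenyl ring. For compound 4 a step of a number 1 percentage points lower from compound 3 to compound 4 (within the scatter) is therefore expected, that is, nothing beyond the scatter. Compound 4 is estimated at 66%, within 52% to 80%.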

Compound 4, a percentage reported as inhibition, in the whole organism at one dose (the size of the read-out at that dose, not a potency): 30%
Compound 4: middle estimate off by 36 percentage points, on the high side; the measured number lies below the stated range.
By their numbers in this assay, from the lowest: compound 4; then compounds 3, 2 and 1 (each within the scatter of the next).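

Swapping 4-methoxyphenyl for 2-methoxyphenyl on the amide nitrogen gives a number 37 percentage points lower from compound 3 to compound 4 (beyond the scatter) in this assay, the first step at this place to go beyond the scatter, although both groups hold the same atoms. The 2-methoxyphenyl group also stands apart from the small chains, with a number 39 percentage points lower from compound 2 to compound 4 (beyond the scatter) and a number 44 percentage points lower from compound 1 to compound 4 (beyond the scatter). So the read-out here depends on where the methoxy sits on the phenyl ring, not only on which atoms are present.

Nothing available explains this drop. Going by these compounds, it also stays open whether a plain phenyl or a 2-ethoxyphenyl group on the amide nitrogen would give a high or a low number.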